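Stereocentre inversion in the ethyl carbamate analogue

A few compounds are considered here, and "the series" means these few. Any claim that something is new, unique, unknown or untested is made for them only; others in the source may bear on it.

Compound 3 `C=C1C(=O)OC[C@@H]1CCOC(=O)Nc1ccc(CC)cc1` gives 1260 nM in a functional assay on RAW264.7 cells (Mus musculus) for inhibition, with a stated time of 30 min (a higher number here means a weaker inhibitor, a lower number a stronger inhibitor), the highest of the three numbers recorded so far. For the measured compounds named here, compound 1 `C=C1C(=O)OC[C@H]1CCOC(=O)Nc1ccc(Cl)cc1` gives 390 nM and compound 2 `C=C1C(=O)OC[C@H]1CCOC(=O)Nc1ccc(Br)cc1` gives 350 nM; the only measured single-point step, a 1.1-fold lower number from compound 1 to compound 2 (0.05 log units; within the scatter), lies within the scatter and concerns the aryl substituent, not the ring. Compound 4 `C=C1C(=O)OC[C@H]1CCOC(=O)Nc1ccc(CC)cc1` differs from compound 3 as follows: the two compounds have the same atoms and bonds and differ only in configuration as drawn: 1 of 1 stereo elements differ; a stereocentre at a saturated ring carbon is drawn R in compound 3 and S in compound 4. Going by the values given here, no measured pair varies only in this stereocentre, so no step bears directly on the change. Compounds 1 and 2 carry the configuration drawn for compound 4, but with other aryl groups, so their numbers cannot be separated from that. The step of a 1.6-fold lower number from compound 3 to compound 4 (0.20 log units; within the scatter) is therefore an open estimate in direction. Compound 4 is expected to give about 800 nM, with a range from 300 nM to 2500 nM.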

Compound 4, half-maximal inhibitory concentration: 840 nM
The estimate for compound 4 lay 1.1-fold (0.02 log units) below the measured number; low and high end bracket the measured number.
By their numbers in this assay, from the lowest: compounds 2 and 1 (each within the scatter of the next); then compounds 4 and 3 (each within the scatter of the next).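

With the aryl group held as ethyl, a 1.5-fold lower number from compound 3 to compound 4 (0.18 log units; within the scatter), so in this assay this stereocentre, inverted in isolation, gives no difference beyond the scatter. The pair reads cleanly as a configuration comparison: the fact that compounds 3 and 4 differ only in the configuration as drawn. At the configuration drawn for compound 4, the aryl substituent does register, with ethyl in place of bromo giving a 2.4-fold higher number from compound 2 to compound 4 (0.38 log units; beyond the scatter) and ethyl in place of chloro giving a 2.2-fold higher number from compound 1 to compound 4 (0.33 log units; beyond the scatter), both modest.

As far as these compounds go, whether inversion is equally silent with chloro or bromo on the aromatic carbon stays open. So does the outcome for a carboxylic acid or a longer alkyl chain there.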